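A dimethylamino side chain on the shared core

The source may report more compounds than this note shows. Statements on the series, on what has been measured and on what is new or still open speak of the compounds shown alone.

Measured compounds in a functional assay on the whole organism with Mus musculus as the target; on this read-out lower numbers stand for an effect already at smaller amounts and higher numbers for an effect only at larger amounts of compound:
compound 1, `Cc1c(C)c2c(c(C)c1N)CC(C)(C)O2`, gives 7.8 mg/kg
compound 2, `Cc1cc2c(c(C)c1N)CC(C)(C)O2`, gives 16.3 mg/kg
compound 3, `Cc1c(N)c(C)c2c(c1CN1CCCCC1)OC(C)(C)C2`, reaches only a limit of the assay, > 50 mg/kg

Among the two numbers, compound 1 stands lowest; its nearest neighbour is compound 2, with a 2.1-fold higher number from compound 1 to compound 2 (0.32 log units; beyond the scatter), brought about by hydrogen in place of methyl on an aromatic carbon. Compound 3 sits at the limit of this assay, (the limit of > 50 mg/kg in this assay, at which 1 of the 3 values shown sits), so its number is not known.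

Compound 4, `Cc1c(C)c2c(c(C)c1N)CC(C)(CCN(C)C)O2`, differs from compound 1 by (dimethylamino)methyl in place of hydrogen on a saturated chain carbon bound to a saturated ring carbon. For the measured compounds named here, two measured steps bear on this change, both attaching a nitrogen-bearing group through a saturated chain carbon: an at least 6.4-fold higher number from compound 1 to compound 3 (0.80 log units; beyond the scatter) and an at least 3.0-fold higher number from compound 2 to compound 3 (0.48 log units; beyond the scatter). Both point the same way, towards a higher number, although each ends at a limit and the new group of compound 4 sits on a saturated chain carbon bound to a saturated ring carbon rather than to an aromatic carbon. The expected step is therefore a 3.2-fold higher number from compound 1 to compound 4 (0.51 log units; beyond the scatter), a modest rise beyond the scatter. For compound 4 in this assay a value of 25 mg/kg is estimated, between 10 mg/kg and 60 mg/kg.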

Compound 4, dose for 50% inhibition: 19 mg/kg
Beside the measured number, compound 4's estimate is 1.3-fold (0.12 log units) above it; the measured number falls inside the stated range.
By their numbers in this assay, from the lowest: compound 1; then compounds 2 and 4 (each within the scatter of the next). At a limit, above all of these: compound 3.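

In this assay, a 2.4-fold higher number from compound 1 to compound 4 (0.39 log units; beyond the scatter) gives the first actual size for a nitrogen-bearing group added to the shared core, as the earlier steps of this kind end at a limit: the limit of > 50 mg/kg in this assay, at which 1 of the 4 values shown sits.

It shows that, on a saturated chain carbon bound to a saturated ring carbon, (dimethylamino)methyl in place of hydrogen leaves a number that can still be read in this assay, and that the step is modest. The same difference, read as methyl to 2-(dimethylamino)ethyl, moves the number up and not down, so compound 1 keeps the lowest number of those shown, with this step beyond the scatter.

On these data alone, it remains open whether the rise comes from the nitrogen or from the longer chain itself, as a plain propyl chain or a 2-hydroxyethyl group at this place would tell. Also open, as far as these compounds go, is how a piperidin-1-yl group on the same chain would compare with dimethylamino, and whether the side chain would act alike with hydrogen in place of methyl on the aromatic carbon, as in compound 2.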